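The source may report more compounds than this note shows. Statements on the series, on what has been measured and on what is new or still open speak of the compounds shown alone.

Compound 1 `CC1CN(C(=O)c2ccc(-c3ccc(NC(=O)Nc4ccc(Cl)c(C(F)(F)F)c4)cc3)cc2)CC(C)O1` and compound 2 `CNC(=O)c1cccc(-c2ccc(NC(=O)Nc3ccc(Cl)c(C(F)(F)F)c3)cc2)c1` share a core and were both run in a functional assay on HepG2 cells (Homo sapiens) for inhibition, read by MTT assay, with a stated time of 120 h; on this read-out higher numbers stand for weaker inhibition and lower numbers for stronger inhibition. In this assay compound 1 gives 31100 nM, and compound 2 gives 37100 nM; the two numbers stand within the scatter of each other, so neither is set apart. Compound 3 `CC(NC(=O)c1ccc(-c2ccc(NC(=O)Nc3ccc(Cl)c(C(F)(F)F)c3)cc2)cc1)c1ccccc1` is not yet measured. It differs from compound 1 by (1-phenylethyl)amino in place of 2,6-dimethylmorpholin-4-yl on a carbonyl carbon. Among the measured compounds shown here, no measured step shows what this change does here, so no shift beyond the scatter is expected; compound 3 is estimated at 25000 nM, between 8000 nM and 70000 nM, an expected step of a 1.2-fold lower number from compound 1 to compound 3 (0.09 log units; within the scatter).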

Compound 3, half-maximal inhibitory concentration: 16800 nM
Beside the measured number, compound 3's estimate is 1.5-fold (0.17 log units) above it; the range from low to high includes it.
By their numbers in this assay, from the lowest: compounds 3, 1 and 2 (each within the scatter of the next, the first and the last beyond it).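

In this assay, (1-phenylethyl)amino in place of 2,6-dimethylmorpholin-4-yl on a carbonyl carbon gives a 1.9-fold lower number from compound 1 to compound 3 (0.27 log units; within the scatter). This position therefore accepts an aromatic ring and an amide hydrogen in place of the non-aromatic ring without a shift beyond the scatter. Nothing available explains the size of this step. The compounds shown leave open whether benzylamino, which lacks the methyl branch of (1-phenylethyl)amino, or piperazin-1-yl on the same carbonyl carbon would move the number beyond the scatter.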